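A Methyl Group Added to the Furan Compound

This account rests on a few compounds, and the source may have more. Where it says the series, first, only, none or still open, it means among the compounds named here.

In a functional assay for inhibition, with Homo sapiens as the target (on this read-out higher numbers stand for weaker inhibition and lower numbers for stronger inhibition), compound 1 (`Cc1cc(C)cc(Nc2nccc(-c3ccccn3)n2)c1`) gives 100 nM. Compound 3 (`Cc1cc(C)cc(Nc2nccc(-c3ccco3)n2)c1`) gives 700 nM, the higher of the two exact numbers in this small set. Replacing pyridin-2-yl with furan-2-yl accounts for a 7.0-fold higher number from compound 1 to compound 3 (0.85 log units; beyond the scatter), a modest step. Compound 2 (`Cc1cc(C)cc(Nc2nc(C)cc(-c3ccccn3)n2)c1`) gives > 24000 nM, which is a limit of the assay and not a number.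

Compound 4 (`Cc1cc(C)cc(Nc2nc(C)cc(-c3ccco3)n2)c1`) carries methyl in place of hydrogen on an aromatic carbon of compound 3: methyl in place of hydrogen on an aromatic carbon. The same replacement has been measured once, with pyridin-2-yl in the molecule, and it produced an at least 240-fold higher number from compound 1 to compound 2 (2.38 log units; beyond the scatter), a large step. This single precedent points to a large rise in the number in this assay, although the size of the step may differ with furan-2-yl present. The reading may well return only a limit. For compound 4 the expected value is 30000 nM, within an estimated range of 6000 nM to 100000 nM. This would be an expected 43-fold higher number from compound 3 to compound 4 (1.63 log units; beyond the scatter).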

Compound 4, half-maximal inhibitory concentration: > 24000 nM
Compound 4 was reported as a limit; the forecaster's own chance of this, stated with the estimate: 70%; the middle value is on the limit's open side.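

In this assay, methyl in place of hydrogen, on the aromatic carbon next to the ring nitrogen, gives an at least 34-fold higher number from compound 3 to compound 4 (1.53 log units; beyond the scatter), a large step showing that the loss of inhibition seen with pyridin-2-yl also occurs with furan-2-yl in the molecule. The change now reads in the same direction on two cores, though its size cannot be compared between them: the same change on two cores in this assay, an at least 240-fold higher number (2.38 log units; beyond the scatter) from compound 1 to compound 2 and an at least 34-fold higher number (1.53 log units; beyond the scatter) from compound 3 to compound 4; the limit leaves it open whether they differ Compound 4, like compound 2, is reported only as a limit: the limit of > 24000 nM in this assay, at which 2 of the 4 values shown sit.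

The step from compound 2 to compound 4 cannot be read, and the compounds shown do not say whether furan-2-yl or pyridin-2-yl does better once the methyl is present. From the compounds shown here alone, it also remains open whether a fluorine atom, an amine or a longer chain at this position would keep inhibition, or whether anything other than hydrogen brings the same loss.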